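A few compounds are considered here, and "the series" means these few. Any claim that something is new, unique, unknown or untested is made for them only; others in the source may bear on it.

Measured in a functional assay on SGC-7901 cells (Homo sapiens) for antiproliferative activity, read by sulforhodamine B assay, with a stated time of 72 h; a lower number here means a stronger inhibitor, a higher number a weaker inhibitor:
compound 1 `N#Cc1ccc(NC(=S)N/N=C/c2ccc3ccccc3n2)cc1` gives 23700 nM
compound 2 `Cc1ccc(NC(=S)N/N=C/c2ccc3ccccc3n2)cc1` gives 92900 nM
compound 3 `COc1cccc(NC(=S)N/N=C/c2ccc3ccccc3n2)c1` gives 79400 nM

Compound 3 sits at the weak end of this small set. Its value cannot be separated from that of compound 2 (a 1.2-fold lower number from compound 2 to compound 3 (0.07 log units; within the scatter)), while compound 1 stands apart (a 3.4-fold higher number from compound 1 to compound 3 (0.53 log units; beyond the scatter)).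

Compound 4 (`Fc1ccc(NC(=S)N/N=C/c2ccc3ccccc3n2)cc1`) has 4-fluorophenyl in place of 3-methoxyphenyl on an amide-type nitrogen.

Three measured steps change the group on this aryl position. Compound 1 marks the only modest gaps (a 3.9-fold higher number from compound 1 to compound 2 (0.59 log units; beyond the scatter)) and (a 3.4-fold higher number from compound 1 to compound 3 (0.53 log units; beyond the scatter)), whereas compound 2 and compound 3 stay within the scatter (a 1.2-fold lower number from compound 2 to compound 3 (0.07 log units; within the scatter)). Going by the values given here, no fluorinated analogue has been measured, so only a small change is expected (a 1.4-fold lower number from compound 3 to compound 4 (0.16 log units; within the scatter)). For compound 4 the estimate is 55000 nM (expected range 23000 nM to 120000 nM).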

Compound 4, half-maximal inhibitory concentration: 32300 nM
For compound 4 the middle estimate is 1.7-fold (0.23 log units) above the measured one; low and high end bracket the measured number.
By their numbers in this assay, from the lowest: compounds 1 and 4 (each within the scatter of the next); then compounds 3 and 2 (each within the scatter of the next).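

In this assay, the change to 4-fluorophenyl separates from 3-methoxyphenyl (a 2.5-fold lower number from compound 3 to compound 4 (0.39 log units; beyond the scatter)), and fluoro separates from methyl (a 2.9-fold lower number from compound 2 to compound 4 (0.46 log units; beyond the scatter)), while fluoro and cyano cannot be told apart (a 1.4-fold higher number from compound 1 to compound 4 (0.13 log units; within the scatter)). Compound 1 is therefore no longer alone: compound 4 shares its low end, and both stand apart from compound 2 and compound 3. Nothing measured here accounts for this grouping.

On these data alone, whether a chloro, a trifluoromethyl or an amine on this aryl ring would fall with compound 1 and compound 4 remains open. So does the place of the plain phenyl.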